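Chloro exchange from compound 3 to compound 4

This account rests on a few compounds, and the source may have more. Where it says the series, first, only, none or still open, it means among the compounds named here.

In an ADME assay (liver) for metabolic stability, with Liver microsome (Rattus norvegicus) as the target, using microsomes and NADPH, with a stated time of 30 min, at 37 degrees C, tested at 1 uM (a higher number here means faster removal of the compound, a lower number slower removal), compound 1 `CC(O)(c1ccc(N2CCN(S(=O)(=O)c3ccc(N)nc3)CC2)cc1)C(F)(F)F` gives < 14 mL.min-1.g-1, which is a limit of the assay. Compound 2 `Nc1ccc(S(=O)(=O)c2ccc(-c3ncc(C(O)(C(F)(F)F)C(F)(F)F)cn3)cc2)cn1` gives < 14 mL.min-1.g-1, also a limit. Within the data shown here, compound 3 `Nc1ccc(S(=O)(=O)c2ccc(-c3ncc(C(O)(C(F)(F)F)C(F)(F)F)cc3Cl)cc2)cn1` reads 18 mL.min-1.g-1, the only actual number in the set. Compound 4 `CC(C)(O)C#Cc1cc(C(O)(C(F)(F)F)C(F)(F)F)cnc1-c1ccc(S(=O)(=O)c2ccc(N)nc2)cc1` carries 3-hydroxy-3-methylbut-1-yn-1-yl in place of chloro on an aromatic carbon, ortho to a large group and two atoms from the ring nitrogen (3-hydroxy-3-methylbut-1-yn-1-yl in place of chloro on an aromatic carbon). Among the measured compounds shown here, no measured pair isolates this exchange, and no firm direction can be assigned. The expected step of a 1.1-fold higher number from compound 3 to compound 4 (0.05 log units; within the scatter) is small and within the usual scatter. The estimated value for compound 4 is 20 mL.min-1.g-1, with an expected range of 12 mL.min-1.g-1 to 38 mL.min-1.g-1.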

Compound 4, intrinsic clearance in microsomes: < 14 mL.min-1.g-1
Compound 4 ended at the assay's limit (the forecaster's own chance of this, stated with the estimate: 30%); middle value at least 1.4-fold (0.15 log units) from the limit.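

In this assay, 3-hydroxy-3-methylbut-1-yn-1-yl in place of chloro, ortho to a large group, gives an at least 1.2-fold lower number from compound 3 to compound 4 (0.10 log units; that floor lies within the scatter). This position therefore accepts a much larger group with a triple bond without any rise in the number. The reading for compound 4 is a limit and not a number, so the true size of the step is unknown, and compound 4 joins the others at the floor: the limit of < 14 mL.min-1.g-1 in this assay, at which 3 of the 4 values shown sit.

As far as these compounds go, whether a carboxylic acid or a morpholine at this position would lift the number above the limit stays open. So does whether a plain methyl or a nitrile would read as chloro does.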